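Amine-to-azetidine swap on the quinone-like core

This account rests on a few compounds, and the source may have more. Where it says the series, first, only, none or still open, it means among the compounds named here.

Measured so far in a functional assay on ECa-109 cells for inhibition, with ECa-109 cell line (Homo sapiens) as the target, read by sulforhodamine B assay; on this read-out lower numbers stand for stronger inhibition and higher numbers for weaker inhibition:
compound 1 `Cc1ccc(NC2=CC(=O)c3nc4n(c3C2=O)[C@H]2OC[C@@H](O)[C@H]2OC4)cc1C`, 2820 nM
compound 2 `COc1ccc(NC2=CC(=O)c3c(nc4n3[C@H]3OC[C@@H](O)[C@H]3OC4)C2=O)cc1`, 3410 nM
compound 3 `O=C1C(Nc2cccc(F)c2)=CC(=O)c2c1nc1n2[C@H]2OC[C@@H](O)[C@H]2OC1`, 2370 nM

Compound 1 stands second highest of the three numbers, with compound 3 nearest and compound 2 furthest; all three lie within the scatter of one another, so no order among them can be read.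

Compound 4 `O=C1C=C(N2CCC2)C(=O)c2c1nc1n2[C@H]2OC[C@@H](O)[C@H]2OC1` is not yet measured. It differs from compound 1 as follows: azetidin-1-yl in place of (3,4-dimethylphenyl)amino on a double-bonded ring carbon. Going by the values given here, the only step measured so far, a 1.4-fold lower number from compound 2 to compound 3 (0.16 log units; within the scatter), exchanges one substituted phenyl for another on the amine nitrogen and stays within the scatter; no measured pair replaces the (3,4-dimethylphenyl)amino group with a ring lacking the aromatic part. The three measured compounds therefore only show that the aryl amines cluster, and give no direct guide for azetidin-1-yl.

Among the compounds with values here, with no bearing step available, a step somewhat upward from compound 1 to compound 4 is expected, a 1.6-fold higher number from compound 1 to compound 4 (0.20 log units; within the scatter), but the uncertainty is wide. Compound 4 is estimated at 4500 nM in this assay, within 1500 nM to 15000 nM.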

Compound 4, half-maximal inhibitory concentration: > 16000 nM
Compound 4 was reported as a limit; the forecaster's own chance of this, stated with the estimate: 15%; at least 3.5-fold (0.55 log units) between middle value and limit.
By their numbers in this assay, from the lowest: compounds 3, 1 and 2 (each within the scatter of the next). At a limit, above all of these: compound 4.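

In this assay compound 4 gives > 16000 nM as a limit of the assay and not a number. The exchange of one substituted phenyl for another on the amine nitrogen gave only a 1.4-fold lower number from compound 2 to compound 3 (0.16 log units; within the scatter) and stayed flat, while azetidin-1-yl in place of (3,4-dimethylphenyl)amino gives an at least 5.6-fold higher number from compound 1 to compound 4 (0.75 log units; beyond the scatter) and so shows that this double-bonded ring carbon does not accept every amine alike. The change removes the six-membered aromatic ring and the hydrogen-bond donor together, and the full size of the step stays unknown, as it rests on a limit: the limit of > 16000 nM in this assay, at which 1 of the 4 values shown sits.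

The compounds shown do not separate those two losses. A cyclohexylamino group would keep the donor without the aromatic ring, and a methyl(phenyl)amino group would keep the aromatic ring without the donor.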